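A few compounds are considered here, and "the series" means these few. Any claim that something is new, unique, unknown or untested is made for them only; others in the source may bear on it.

The series shares one core. Compound 1 `FC(F)(F)c1ccc(Nc2nc(N3CCN(C4CCC4)CC3)nc3c2CCN(c2ncccc2C(F)(F)F)CC3)cc1` carries a 4-cyclobutylpiperazin-1-yl group on an aromatic carbon, and in a functional assay on HEK293 cells for antagonist activity at transient receptor potential cation channel subfamily V member 1 (Homo sapiens), read by FLIPR and calcium flux (a lower number here means a stronger inhibitor, a higher number a weaker inhibitor), compound 1 gives 24 nM. Compound 2 `CN(c1nc2c(c(Nc3ccc(C(F)(F)F)cc3)n1)CCN(c1ncccc1C(F)(F)F)CC2)C1CCCNC1` differs in one place, methyl(piperidin-3-yl)amino in place of 4-cyclobutylpiperazin-1-yl on an aromatic carbon, and in this assay compound 2 gives 3600 nM. Among the compounds with values here, that is the highest of the two numbers measured so far, the step being a 150-fold higher number from compound 1 to compound 2 (2.18 log units; beyond the scatter).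

Compound 3 `CNC1CCN(c2nc3c(c(Nc4ccc(C(F)(F)F)cc4)n2)CCN(c2ncccc2C(F)(F)F)CC3)C1` is the next variation at the same aromatic carbon: 3-(methylamino)pyrrolidin-1-yl in place of methyl(piperidin-3-yl)amino on an aromatic carbon. Within the data shown here, only one measured step bears on this position, and it was large; it shows that this part of the molecule moves the number strongly, but it does not show where a 3-(methylamino)pyrrolidin-1-yl group falls. Compound 3 returns to a group attached through a ring nitrogen, as in compound 1, so the number for compound 3 is expected to fall from the value of compound 2, by a 9.0-fold lower number from compound 2 to compound 3 (0.95 log units; beyond the scatter), with wide uncertainty. Compound 3 is therefore estimated at 400 nM, within 80 nM to 2000 nM.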

Compound 3, half-maximal inhibitory concentration: 2790 nM
Estimate against measurement, compound 3: 7.0-fold (0.84 log units) below; the whole stated range lies below it.
By their numbers in this assay, from the lowest: compound 1; then compounds 3 and 2 (each within the scatter of the next).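

In this assay, putting 3-(methylamino)pyrrolidin-1-yl in place of methyl(piperidin-3-yl)amino gives a 1.3-fold lower number from compound 2 to compound 3 (0.11 log units; within the scatter), so the five-membered ring attached through its ring nitrogen and the six-membered ring attached through an exocyclic nitrogen cannot be told apart at this aromatic carbon. Attachment through a ring nitrogen is therefore not enough on its own to reach the number of compound 1: with 3-(methylamino)pyrrolidin-1-yl in place of 4-cyclobutylpiperazin-1-yl the change is a 120-fold higher number from compound 1 to compound 3 (2.07 log units; beyond the scatter), a large step of about the same size as the one seen for the other group. Nothing measured here explains the gap between 4-cyclobutylpiperazin-1-yl and the two smaller amines.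

The compounds shown leave open which part of 4-cyclobutylpiperazin-1-yl matters, the piperazine ring or the cyclobutyl group on it. A piperazin-1-yl group with no substituent, or one carrying a methyl or a cyclopropyl group in place of the cyclobutyl, would separate the two, and a cyclobutyl group on the amine of 3-(methylamino)pyrrolidin-1-yl would test whether that group carries over to another ring.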